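Flipping the double bond: E to Z in compound 3

A few compounds are considered here, and "the series" means these few. Any claim that something is new, unique, unknown or untested is made for them only; others in the source may bear on it.

Of the compounds shown here, two have been measured in an assay on CHO cells for antagonist activity at transient receptor potential cation channel subfamily V member 1 (Homo sapiens), read by FLIPR and calcium flux (a higher number here means a weaker inhibitor, a lower number a stronger inhibitor), so far. Compound 1 `CC(C(=O)NCc1ccc(C(F)(F)F)nc1C1=CCCCC1)c1ccc(NS(C)(=O)=O)c(F)c1` gives 0.7 nM. Compound 2 `CCC/C=C/c1nc(C(F)(F)F)ccc1CNC(=O)C(C)c1ccc(NS(C)(=O)=O)c(F)c1` carries a pent-1-en-1-yl chain where compound 1 carries a cyclohex-1-en-1-yl ring; in this assay compound 2 gives 0.9 nM. Going by the values given here, the only step between them, a 1.3-fold higher number from compound 1 to compound 2 (0.11 log units; within the scatter), shows that exchanging the ring for the open chain changes little, and compound 2 therefore sits level with compound 1 rather than apart from it.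

Compound 3 `CCC/C=C\c1nc(C(F)(F)F)ccc1CNC(=O)C(C)c1ccc(NS(C)(=O)=O)c(F)c1` differs from compound 2 only in geometry: the two compounds have the same atoms and bonds; at least one stereo element is drawn with a configuration in one of them and without one in the other: 1 of 2 stereo elements differ; a double bond is drawn E in compound 2 and Z in compound 3. Among the compounds with values here, no measured step here alters the shape of a double bond, so nothing measured speaks directly to this change. Given that compound 1 and compound 2 lie within the scatter of each other, the expectation for compound 3 is a small shift at most, a 1.7-fold higher number from compound 2 to compound 3 (0.22 log units; within the scatter), and compound 3 is estimated at 1.5 nM in this assay, within a range from 0.5 nM to 6 nM.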

Compound 3, inhibition constant: 2.1 nM
Beside the measured number, compound 3's estimate is 1.4-fold (0.15 log units) below it; the measured number falls inside the stated range.
By their numbers in this assay, from the lowest: compounds 1 and 2 (each within the scatter of the next); then compound 3.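

In this assay, the shape of the double bond matters at this position even though no atom or bond changes: the flip from E to Z gives a 2.3-fold higher number from compound 2 to compound 3 (0.37 log units; beyond the scatter), a modest step but a real one. The earlier swap of ring for chain stayed within the scatter, so it suggested that this position tolerates change, but the Z chain does not keep level with the ring, as the step of a 3.0-fold higher number from compound 1 to compound 3 (0.48 log units; beyond the scatter) shows. The one recorded fact at this place concerns how the structures are drawn, and it gives no measured cause for the shift: the fact that one of compounds 2 and 3 is drawn with a defined configuration and the other without, at the place where they differ

The compounds shown leave open where a saturated pentyl chain would fall relative to the E and Z chains. They also leave open whether a longer chain, such as hept-1-en-1-yl, would show the same gap between its two double-bond forms.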